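Sulfone series: dimethoxyphenyl to cyanophenyl on the sulfonyl

The source may report more compounds than this note shows. Statements on the series, on what has been measured and on what is new or still open speak of the compounds shown alone.

Compound 2 `COc1ccc(S(=O)(=O)c2cnc3ccc(Cl)cc3c2N2CCC(C)CC2)cc1OC` gives 61% in an assay on isolated protein for displacement of a labelled ligand from metabotropic glutamate receptor 5 (Homo sapiens), with a stated time of 60 min, tested at 1 uM; a lower number here means less inhibition, a higher number more inhibition at the concentration tested (going by the name of the read-out). Compound 1 `Cc1ccc2ncc(S(=O)(=O)c3ccc(C#N)cc3)c(N3CCC(C)CC3)c2c1` gives 55% in this assay; the two numbers lie within the scatter of each other, so neither stands apart. Compound 3 `CC1CCN(c2c(S(=O)(=O)c3ccc(C#N)cc3)cnc3ccc(Cl)cc23)CC1` is not yet measured. It differs from compound 2 by 4-cyanophenyl in place of 3,4-dimethoxyphenyl on a sulfonyl sulfur. Going by the values given here, no step between measured compounds covers this change, and compound 1, which also carries 4-cyanophenyl, is not separated from compound 2 beyond the scatter. The step expected in this assay is none beyond the scatter, a number 3 percentage points lower from compound 2 to compound 3 (within the scatter). For compound 3 the estimated value in this assay is 58%, with a range from 40% to 76%.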

Compound 3, a percentage reported as inhibition, at one concentration (the size of the read-out at that concentration, not a potency): 31%
Estimate against measurement, compound 3: 27 percentage points above, outside the stated range (below it).
By their numbers in this assay, from the lowest: compound 3; then compounds 1 and 2 (each within the scatter of the next).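

In this assay the aryl group on the sulfonyl sulfur matters with the chloro held constant: 4-cyanophenyl in place of 3,4-dimethoxyphenyl gives a number 30 percentage points lower from compound 2 to compound 3 (beyond the scatter) and so this position is not indifferent to the change. With 4-cyanophenyl held constant, chloro in place of methyl on an aromatic carbon gives a number 24 percentage points lower from compound 1 to compound 3 (beyond the scatter) and so the 4-cyanophenyl result also depends on that second place, which compound 1 and compound 2 alone did not show. No measurement at hand gives a reason for either step.

Open, as far as these compounds go, is how 3,4-dimethoxyphenyl behaves with methyl in place of chloro. Also open, from the compounds shown here alone, is what a single methoxy, or an amine or carboxylic acid in place of the nitrile, would give on the phenyl ring.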